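The compounds below may be only part of what the source reports. "The series", "measured", "known", "first", "only" and "open" are said of these compounds alone.

Working notes on the squalene synthase series.

Among the compounds with values here, compound 1, `C=CCc1ccccc1OCCCNC(C)C`, is the weaker of the two compounds measured so far. In an assay for inhibition of squalene synthase (Rattus norvegicus), using microsomes (on this read-out higher numbers stand for weaker inhibition and lower numbers for stronger inhibition), compound 1 gives 56 nM. Within the data shown here, compound 2, `CCC(=O)Nc1ccc(OCCCNC(C)C)c(Cc2ccccc2)c1`, carries a propanamide nitrogen and a benzyl group on its core and in this assay compound 2 gives 0.6 nM; the gap between the two values is well beyond the usual scatter, and no single-point step connects these two structures, so nothing more than the two numbers themselves can be read from the pair.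

Compound 3, `C=CCc1cc(N)ccc1OCCCNC(C)C`, differs from compound 1 in one place: amino in place of hydrogen on an aromatic carbon. A ring nitrogen substituent is also present in compound 2, whose value in this assay is 0.6 nM, but that compound differs from compound 1 in more than one place, so the contribution of the ring nitrogen alone is not known here.

The step from compound 1 to compound 3 is expected to be a modest gain in potency, of the order of a 2.8-fold lower number from compound 1 to compound 3 (0.45 log units; beyond the scatter), larger than the scatter but far short of the gap to compound 2. For compound 3 in this assay the estimate is 20 nM, within a range of 5 nM to 70 nM.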

Compound 3, half-maximal inhibitory concentration: 250 nM
Beside the measured number, compound 3's estimate is 13-fold (1.10 log units) below it, outside the stated range (above it).
By their numbers in this assay, from the lowest: compound 2; then compound 1; then compound 3.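

In this assay, amino in place of hydrogen on the aromatic carbon meta to an allyl group and para to a group of 8 heavy atoms gives a 4.5-fold higher number from compound 1 to compound 3 (0.65 log units; beyond the scatter), so on the core of compound 1 this change weakens inhibition by more than the scatter. This single-place step gives a direct reading of this position, which compound 2 could not give, as compound 2 differs from compound 1 in more than one place. No measurement at hand bears on what lies behind the direction or the size of this step.

Still open, from the compounds shown here alone, is how other groups on this same aromatic carbon would read against the hydrogen of compound 1, for instance a hydroxyl, a methoxy or an acetamide, and so whether the loss belongs to amino alone or to any substituent there. Also open is whether the same amino step would have the same direction and size with a benzyl group in place of the allyl group, since the compounds shown hold no pair that reads this step on a benzyl-bearing core.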